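From Benzoyl to (Thiophen-2-yl)sulfonyl in a Cytotoxicity Series

The source may hold more compounds than are shown below. What is called first, only, known or untested is meant among the compounds shown, and "the series" means these compounds.

Measured in a functional assay on A-431 cells (Homo sapiens) for cytotoxicity, read by MTT assay, with a stated time of 48 h; a higher number here means a weaker inhibitor, a lower number a stronger inhibitor:
Compound 1 `CCCCCCCCNC(=O)[C@@H](NC(=O)c1ccccc1)[C@@H](C)O`: 61300 nM
Compound 2 `CCCCCCCCCCCCNC(=O)[C@@H](NC(=O)c1ccccc1)[C@@H](C)O`: 41200 nM
Compound 3 `CCCCCCCCCCCCNC(=O)[C@@H](NC(=O)c1nccc2ccccc12)[C@@H](C)O`: 62800 nM

Compound 2 has the lowest of the three numbers, but its neighbours sit close: a 1.5-fold lower number from compound 1 to compound 2 (0.17 log units; within the scatter) and a 1.5-fold higher number from compound 2 to compound 3 (0.18 log units; within the scatter) are both within the scatter, so no order among the three can be claimed. Compound 4 `CCCCCCCCCCCCNC(=O)[C@@H](NS(=O)(=O)c1cccs1)[C@@H](C)O` differs from compound 2 by (thiophen-2-yl)sulfonyl in place of benzoyl on an amine nitrogen. Neither measured step bears directly on this change; the nearest is the aryl swap on the carbonyl carbon, a 1.5-fold higher number from compound 2 to compound 3 (0.18 log units; within the scatter), which stayed within the scatter. Compound 4 is therefore expected to show no step beyond the scatter, a 1.1-fold higher number from compound 2 to compound 4 (0.04 log units; within the scatter). The estimated value for compound 4 is 45000 nM, between 15000 nM and 140000 nM.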

Compound 4, half-maximal inhibitory concentration: 22000 nM
Compound 4: middle estimate off by 2.0-fold (0.31 log units), on the high side; measured number inside the range.
By their numbers in this assay, from the lowest: compounds 4, 2, 1 and 3 (each within the scatter of the next, the first and the last beyond it).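

At this amine nitrogen, the amide-type benzoyl link gives way to a sulfonyl link bearing a five-membered ring, and in this assay the change brings a 1.9-fold lower number from compound 2 to compound 4 (0.27 log units; within the scatter). The position therefore tolerates a change of both linker and ring without a step beyond the scatter. No evidence is available to account for this result.

Since linker and ring change together, the compounds shown leave open what each contributes alone. Phenylsulfonyl and thiophene-2-carbonyl on the same nitrogen would separate the two.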